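Swapping methoxy for trifluoromethyl in compound 2

The source may report more compounds than this note shows. Statements on the series, on what has been measured and on what is new or still open speak of the compounds shown alone.

Of the compounds shown here, three with closely related structures have been measured so far. In a functional assay with Rattus norvegicus as the target (on this read-out higher numbers stand for weaker inhibition and lower numbers for stronger inhibition), compound 2 `COc1ccc2oc(=O)c(=O)[nH]c2c1` gives 15000 nM, the second highest of the three numbers. Compound 1 `COc1cccc2[nH]c(=O)c(=O)oc12` sits lower at 7000 nM, and compound 3 `O=c1[nH]c2ccc(O)cc2oc1=O` sits much higher at 170000 nM.

The next compound changes one group of compound 2. Compound 4 `O=c1[nH]c2cc(C(F)(F)F)ccc2oc1=O` carries trifluoromethyl in place of methoxy on an aromatic carbon. Within the data shown here, no measured pair shows this swap, so the expectation is a judgement with little direct support. The spread between compound 1 at 7000 nM and compound 3 at 170000 nM does show that numbers in this small set can differ widely, so a step of real size is plausible.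

A modest move towards stronger inhibition is expected, with the estimated step of a 2.1-fold lower number from compound 2 to compound 4 (0.33 log units; beyond the scatter), though a result within the scatter would not be surprising. For compound 4 the estimated value is 7000 nM, with an expected range from 1800 nM to 28000 nM.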

Compound 4, half-maximal inhibitory concentration: 100000 nM
Beside the measured number, compound 4's estimate is 14-fold (1.15 log units) below it, outside the stated range (above it).
By their numbers in this assay, from the lowest: compound 1; then compound 2; then compounds 4 and 3 (each within the scatter of the next).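

In this assay, trifluoromethyl in place of methoxy on this aromatic carbon weakens inhibition (a 6.7-fold higher number from compound 2 to compound 4 (0.82 log units; beyond the scatter)), the opposite of a gain. This is the only pair shown that differs in one place, so it gives the first direct sign that the group on this carbon matters and that methoxy cannot be exchanged for trifluoromethyl without a loss. No measurement shown here bears on why inhibition falls, so this single swap cannot tell which difference between the two groups counts.

Still open, going by these compounds, is how other groups would behave on the same aromatic carbon, such as an amine, a carboxylic acid or a longer chain. On these data alone, it is also open whether the same swap would have a similar effect at another position on the shared core.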